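A Fluorophenyl in Place of the Bromothiophene of Compound 1

A few compounds are considered here, and "the series" means these few. Any claim that something is new, unique, unknown or untested is made for them only; others in the source may bear on it.

Compound 1 `O=C1N=C(N2CCC[C@H]2C(=O)Nc2ccc3ncnc(Nc4cccc(Cl)c4)c3c2)S/C1=C/c1ccc(Br)s1` is the starting point. In a functional assay on HepG2 cells (Homo sapiens) for antiproliferative activity, read by MTT assay (a higher number here means a weaker inhibitor, a lower number a stronger inhibitor), compound 1 gives only a limit of the assay, > 50000 nM, as recorded in the limit of > 50000 nM in this assay, at which 1 of the 3 values shown sits. Compound 2 `O=C1N=C(N2CCC[C@H]2C(=O)Nc2ccc3ncnc(Nc4cccc(Cl)c4)c3c2)S/C1=C/c1cccc(Br)c1` gives 21300 nM in this assay, and compound 3 `COc1ccccc1/C=C1/SC(N2CCC[C@H]2C(=O)Nc2ccc3ncnc(Nc4cccc(Cl)c4)c3c2)=NC1=O` gives 22100 nM. The two steps away from compound 1, an at least 2.3-fold lower number from compound 1 to compound 2 (0.37 log units; beyond the scatter) and an at least 2.2-fold lower number from compound 1 to compound 3 (0.35 log units; beyond the scatter), point the same way, while between the other pair there is a 1.0-fold higher number from compound 2 to compound 3 (0.02 log units; within the scatter). Compound 4 `O=C1N=C(N2CCC[C@H]2C(=O)Nc2ccc3ncnc(Nc4cccc(Cl)c4)c3c2)S/C1=C/c1ccccc1F` differs from compound 1 by 2-fluorophenyl in place of 5-bromothiophen-2-yl on a double-bonded chain carbon bound to a double-bonded ring carbon. This change resembles the two measured steps, so a step of at least modest size toward a lower number is expected, an at least 2.2-fold lower number from compound 1 to compound 4 (0.35 log units; beyond the scatter). Compound 4 is therefore estimated to give about 22000 nM in this assay, within 8000 nM to 60000 nM.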

Compound 4, half-maximal inhibitory concentration: 18200 nM
Compound 4: the middle estimate sits 1.2-fold (0.08 log units) above what was measured; measured number inside the range.
By their numbers in this assay, from the lowest: compounds 4, 2 and 3 (each within the scatter of the next). At a limit, above all of these: compound 1.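

On these data alone, with 2-fluorophenyl at this position there is an at least 2.7-fold lower number from compound 1 to compound 4 (0.43 log units; beyond the scatter), a step read against a limit of the assay, so its full size stays unknown. Fluoro and methoxy on an aromatic carbon read alike, with a 1.2-fold lower number from compound 3 to compound 4 (0.08 log units; within the scatter), and 2-fluorophenyl and 3-bromophenyl also read alike, with a 1.2-fold lower number from compound 2 to compound 4 (0.07 log units; within the scatter). In this assay, compound 2, compound 3 and compound 4 thus form one level, with compound 1 the exception. As far as these compounds go, whether an amine or a carboxylic acid on the phenyl ring would depart from that level stays open, as does whether a thiophene without bromine would stay with compound 1.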